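A few compounds are considered here, and "the series" means these few. Any claim that something is new, unique, unknown or untested is made for them only; others in the source may bear on it.

The measured compounds and their values:

- compound 1, `C#CCn1nnc2c(C(N)=O)ncn2c1=O`: in a functional assay on U-373MG ATCC cells for inhibition, with U373 MG (Homo sapiens) as the target, read by MTT assay, with a stated time of 7 days (a lower number here means a stronger inhibitor of growth, a higher number a weaker inhibitor of growth), compound 1 gives 37600 nM
- compound 2, `NC(=O)c1ncn2c(=O)n(Cc3ccccc3)nnc12`: for compound 2 the result is only a limit of the assay, > 50000 nM
- compound 3, `C#CC/N=N/Nc1[nH]cnc1C(N)=O`: compound 3 gives 32000 nM

Compound 1 and compound 3 share an amide-bearing core, but the difference between the two cores is not broken down here. Compound 1 and compound 2 differ in one place, (phenyl in place of ethynyl on a saturated chain carbon bound to an aromatic nitrogen), and the step was an at least 1.3-fold higher number from compound 1 to compound 2 (0.12 log units; that floor lies within the scatter), with the value of compound 2 sitting at the limit of > 50000 nM in this assay, at which 1 of the 3 values shown sits.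

Compound 4, `NC(=O)c1nc[nH]c1N/N=N/Cc1ccccc1`, has not yet been measured. It differs from compound 3 by phenyl in place of ethynyl on a saturated chain carbon bound to a double-bonded nitrogen. The place is not the same as in compound 1: the saturated chain carbon is bound to a double-bonded nitrogen rather than to an aromatic nitrogen, so this is the same kind of change, not the same one. The step to compound 4 in this assay is expected to be a 1.7-fold higher number from compound 3 to compound 4 (0.24 log units; within the scatter), resting on the step seen from compound 1 to compound 2, an at least 1.3-fold higher number from compound 1 to compound 2 (0.12 log units; that floor lies within the scatter). For compound 4 the expected value is 55000 nM, with a range from 25000 nM to 150000 nM, and the assay may well return only a limit.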

Compound 4, concentration for 50% growth inhibition: > 50000 nM
Compound 4 gave a limit, no number; the forecaster's own chance of this, stated with the estimate: 60%; the middle value lies beyond the limit too.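

In this assay, compound 4 returned only a limit of the assay, > 50000 nM, not a true number. Placing phenyl in place of ethynyl on this core gives an at least 1.5-fold higher number from compound 3 to compound 4 (0.19 log units; that floor lies within the scatter), so the data show that the number may have risen, but not that it truly did. The change made on the core of compound 1 and on the core of compound 3 ends in a limit both times, which fits with the change carrying over from one core to the other, but it cannot show that the effect has the same size on both: the same change on two cores in this assay, an at least 1.3-fold higher number (0.12 log units; that floor lies within the scatter) from compound 1 to compound 2 and an at least 1.5-fold higher number (0.19 log units; that floor lies within the scatter) from compound 3 to compound 4; the limit leaves it open whether they differ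

The compounds shown carry only ethynyl or phenyl on the saturated chain carbon, so it remains open how an amine, a carboxylic acid or a longer chain in that place would read in this assay. Going by these compounds, it also remains open whether any of these groups would shift the number by a similar amount on both cores.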